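Aryl piperazine dithiocarbamates: position of compound 3, outlook for compound 4

The source may report more compounds than this note shows. Statements on the series, on what has been measured and on what is new or still open speak of the compounds shown alone.

Measured compounds:
compound 1 `Nc1ccccc1NC(=O)c1ccc(CSC(=S)N2CCN(c3ccc(Cl)cc3)CC2)cc1` gives 17.2%
compound 2 `Nc1ccccc1NC(=O)c1ccc(CSC(=S)N2CCN(c3ccccc3)CC2)cc1` gives 87.4%
compound 3 `Nc1ccccc1NC(=O)c1ccc(CSC(=S)N2CCN(c3cccnc3)CC2)cc1` gives 76.9%

In a functional assay on MGC-803 cells (Homo sapiens) for antiproliferative activity, read by CCK-8 assay, with a stated time of 72 h, tested at 8 uM (a higher number here means a stronger effect of the compound at the concentration tested, a lower number a weaker effect), compound 3 stands second of the three numbers, sitting a number 10.5 percentage points lower from compound 2 to compound 3 (beyond the scatter) and standing far above compound 1, as seen in a number 59.7 percentage points higher from compound 1 to compound 3 (beyond the scatter). Compound 4 `COc1ccc(N2CCN(C(=S)SCc3ccc(C(=O)Nc4ccccc4N)cc3)CC2)cc1` differs from compound 3 only in the group on the ring nitrogen: 4-methoxyphenyl in place of pyridin-3-yl on an amine nitrogen in a ring. Among the compounds with values here, three steps bear on this change, all at the same place: the large a number 70.2 percentage points higher from compound 1 to compound 2 (beyond the scatter), the large a number 59.7 percentage points higher from compound 1 to compound 3 (beyond the scatter), and the modest a number 10.5 percentage points lower from compound 2 to compound 3 (beyond the scatter). A 4-chlorophenyl group here gave by far the lowest number, whereas phenyl and pyridin-3-yl both stand well above it, as the two large steps show; 4-methoxyphenyl has not been measured on this ring nitrogen, so the expectation is wide. A downward step is expected, a number 31.9 percentage points lower from compound 3 to compound 4 (beyond the scatter), in this assay. Compound 4 is estimated at 45%, with a range from 10% to 85%.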

Compound 4, a percentage reported as inhibition, at one concentration (the size of the read-out at that concentration, not a potency): 22.9%
Compound 4: middle estimate off by 22.1 percentage points, on the high side; the range from low to high includes it.
By their numbers in this assay, from the lowest: compounds 1 and 4 (each within the scatter of the next); then compound 3; then compound 2.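

The low number of compound 1 is not confined to chloro: in this assay, methoxy in place of hydrogen on the aromatic carbon gives a number 64.5 percentage points lower from compound 2 to compound 4 (beyond the scatter), and methoxy in place of chloro gives a number 5.7 percentage points higher from compound 1 to compound 4 (within the scatter). The change from pyridin-3-yl to 4-methoxyphenyl gives a number 54 percentage points lower from compound 3 to compound 4 (beyond the scatter), so among the four groups shown, 4-chlorophenyl and 4-methoxyphenyl both sit low, while phenyl and pyridin-3-yl sit high. No measurement available here explains this. Going by these compounds, whether 4-fluorophenyl, 4-methylphenyl or 4-aminophenyl would also sit low remains open.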